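The source may hold more compounds than are shown below. What is called first, only, known or untested is meant among the compounds shown, and "the series" means these compounds.

Measured so far in a functional assay on MCF7 cells (Homo sapiens) for antiproliferative activity, read by XTT assay, with a stated time of 72 h; on this read-out higher numbers stand for weaker inhibition and lower numbers for stronger inhibition:
compound 1 `COc1ccc(-c2cc3ccccc3nc2/C=C/C(=O)c2ccc(N)cc2)cc1` gives 6920 nM
compound 2 `COc1ccc(-c2cc3ccccc3nc2/C=C/C(=O)c2ccco2)cc1` gives 710 nM
compound 3 `COc1ccc(-c2cc3ccccc3nc2/C=C/C(=O)c2ccc(Br)s2)cc1` gives 910 nM

Compound 3 has the second highest of the three numbers in this assay. Its nearest neighbour is compound 2, which lies within the scatter of it (a 1.3-fold higher number from compound 2 to compound 3 (0.11 log units; within the scatter)); its furthest is compound 1, beyond the scatter (a 7.6-fold lower number from compound 1 to compound 3 (0.88 log units; beyond the scatter)). Both five-membered heteroaryl ketones sit well apart from the 4-aminophenyl ketone of compound 1 (a 9.7-fold lower number from compound 1 to compound 2 (0.99 log units; beyond the scatter)).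

The next compound, compound 4 `COc1ccc(-c2cc3ccccc3nc2/C=C/C(=O)c2ccsc2)cc1`, differs from compound 3 in one place: thiophen-3-yl in place of 5-bromothiophen-2-yl on a carbonyl carbon. For the measured compounds named here, the only measured step that bears directly on it is the swap of one five-membered heteroaryl for another, furan-2-yl to 5-bromothiophen-2-yl, which stayed within the scatter (a 1.3-fold higher number from compound 2 to compound 3 (0.11 log units; within the scatter)). Nothing measured here tells what removing the bromine or moving the attachment point of the thiophene does on its own. The expectation for compound 4 in this assay is therefore a step of no more than the scatter from compound 3 (a 1.2-fold higher number from compound 3 to compound 4 (0.08 log units; within the scatter)), with the range widened for the untested change.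

Compound 4 is estimated at 1100 nM, between 450 nM and 2700 nM.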

Compound 4, half-maximal inhibitory concentration: 6010 nM
Beside the measured number, compound 4's estimate is 5.5-fold (0.74 log units) below it; the whole stated range lies below it.
By their numbers in this assay, from the lowest: compounds 2 and 3 (each within the scatter of the next); then compounds 4 and 1 (each within the scatter of the next).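

In this assay the group on the carbonyl carbon proves more sensitive than the close pair of compound 2 and compound 3 implied, since thiophen-3-yl in place of 5-bromothiophen-2-yl moves the number well beyond the scatter (a 6.6-fold higher number from compound 3 to compound 4 (0.82 log units; beyond the scatter)), and thiophen-3-yl in place of furan-2-yl does the same (an 8.5-fold higher number from compound 2 to compound 4 (0.93 log units; beyond the scatter)). A five-membered aromatic ring with one hetero atom on the carbonyl carbon is therefore not enough on its own to hold the lower numbers: compound 4 goes against the earlier split of five-membered heteroaryl ketones from the 4-aminophenyl ketone, and it lies within the scatter of that ketone (a 1.2-fold lower number from compound 1 to compound 4 (0.06 log units; within the scatter)). No measurement on hand accounts for the change at this position.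

The step from compound 3 to compound 4 removes the bromine and changes the thiophene attachment point together, so the share of each stays unresolved. Thiophen-2-yl without bromine and furan-3-yl would separate the two, and would show whether the attachment point or the bromine carries the difference.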